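Trading trifluoromethyl for hydrogen in compound 2

A few compounds are considered here, and "the series" means these few. Any claim that something is new, unique, unknown or untested is made for them only; others in the source may bear on it.

In a functional assay on the whole organism with Mus musculus as the target, in the writhing test (on this read-out lower numbers stand for an effect already at smaller amounts and higher numbers for an effect only at larger amounts of compound), compound 1 (`FC(F)(F)CCCSc1nsnc1C1CN2CCCC1C2`) gives 0.1 mg/kg and compound 2 (`FC(F)(F)CCCCSc1nsnc1[C@@H]1CN2CCC[C@@H]1C2`) gives 0.07 mg/kg. These two numbers lie within the usual scatter of each other, so compound 2 stands level with compound 1 and no order can be read between them. Compound 3 (`CCCCSc1nsnc1[C@@H]1CN2CCC[C@@H]1C2`) keeps the core of compound 2 but carries hydrogen in place of trifluoromethyl on a saturated chain carbon, four bonds along the chain from a sulfur. Among the compounds with values here, no measured pair isolates this change, so the data give no size for it. A move toward a higher number in this assay, somewhat beyond the scatter, is nonetheless expected, and the estimated step is a 2.9-fold higher number from compound 2 to compound 3 (0.46 log units; beyond the scatter). Compound 3 is expected at 0.2 mg/kg, with an estimated range of 0.05 mg/kg to 0.8 mg/kg.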

Compound 3, dose for half-maximal effect: 0.19 mg/kg
For compound 3 the middle estimate is 1.1-fold (0.02 log units) above the measured one; the measured number falls inside the stated range.
By their numbers in this assay, from the lowest: compounds 2, 1 and 3 (each within the scatter of the next, the first and the last beyond it).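

In this assay, the change of trifluoromethyl to hydrogen on a saturated chain carbon, four bonds along the chain from a sulfur, now has a measured size: a 2.7-fold higher number from compound 2 to compound 3 (0.43 log units; beyond the scatter), a modest step that lies beyond the usual scatter. The position therefore responds to this change, yet the trifluoromethyl group is not needed for an effect in this test, as compound 3 still gives 0.19 mg/kg. Nothing in the available data explains the step.

The compounds shown leave open how other groups at this chain end, such as a hydroxyl, an amine or a carboxylic acid, would compare with hydrogen and trifluoromethyl. Going by these compounds, it also remains open whether the same exchange would give a step of similar size on a shorter or longer chain.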